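A few compounds are considered here, and "the series" means these few. Any claim that something is new, unique, unknown or untested is made for them only; others in the source may bear on it.

In a functional assay on HepG2 cells (Homo sapiens) for antiproliferative activity, read by MTT assay, with a stated time of 48 h (on this read-out lower numbers stand for stronger inhibition and higher numbers for weaker inhibition), compound 1 `C#Cc1cccc(Nc2ncnc3cc(NC(=O)/C=C/c4ccccc4)sc23)c1` gives 15400 nM, and compound 2 `N#Cc1cccc(Nc2ncnc3cc(NC(=O)/C=C/c4ccccc4)sc23)c1` gives 15900 nM. Within the data shown here, these two numbers lie within the usual scatter of each other, so compound 2 cannot be ranked against its only measured neighbour. Compound 3 `O=C(/C=C/c1ccccc1)Nc1cc2ncnc(Nc3ccc(F)c(Cl)c3)c2s1` keeps the shared core and the amide side of compound 2. The difference is 3-chloro-4-fluorophenyl in place of 3-cyanophenyl on a nitrogen on an aromatic ring. Among the measured compounds shown here, the only measured step that bears on this is a 1.0-fold higher number from compound 1 to compound 2 (0.01 log units; within the scatter), with cyano in place of ethynyl on an aromatic carbon. On this single step, no change beyond the scatter is expected in this assay, in either direction. The evidence is thin, since neither measured compound carries chlorine or fluorine. The expected change is a 1.1-fold lower number from compound 2 to compound 3 (0.06 log units; within the scatter). The estimate for compound 3 is 14000 nM, with an expected range of 6000 nM to 32000 nM.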

Compound 3, half-maximal inhibitory concentration: 10600 nM
Compound 3: the middle estimate sits 1.3-fold (0.12 log units) above what was measured; the range from low to high includes it.
By their numbers in this assay, from the lowest: compounds 3, 1 and 2 (each within the scatter of the next).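

In this assay the 3-chloro-4-fluorophenyl group on the nitrogen gives a 1.5-fold lower number from compound 2 to compound 3 (0.18 log units; within the scatter) and a 1.5-fold lower number from compound 1 to compound 3 (0.16 log units; within the scatter) and neither step lies beyond the scatter. Compound 1 and compound 2 alone compared only an ethynyl group with a nitrile on this ring, whereas compound 3 shows that a ring with chlorine and fluorine and no triple bond also gives a number that cannot be separated from theirs. No measurement at hand offers an explanation for this result.

From the compounds shown here alone, it remains open whether any group on this ring can move the number beyond the scatter, as an amine or a carboxylic acid there might. Going by these compounds, it is also open whether the ring is needed at all, which a short alkyl chain on the nitrogen in its place would test.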